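This account rests on a few compounds, and the source may have more. Where it says the series, first, only, none or still open, it means among the compounds named here.

Measured compounds in a functional assay on Huh-7 cells (Homo sapiens), read by fluorescence and BrdU incorporation, with a stated time of 48 h, tested at 10 uM; on this read-out lower numbers stand for a stronger effect and higher numbers for a weaker effect at the one concentration tested:
Compound 1 `COc1cc(OC)c(C(=O)/C=C/c2ccccc2SC)c(OC)c1` gives 37%.
Compound 2 `COc1cccc(/C=C/C(=O)c2c(OC)cc(OC)cc2OC)c1` gives 40%.
Compound 3 `COc1cc(OC)c(C(=O)/C=C/c2ccccc2)c(OC)c1` gives 45%.

Compound 2 stands second highest of these three numbers, with compound 1 nearest and compound 3 furthest, both within the scatter. The shown steps are all small: a number 3 percentage points higher from compound 1 to compound 2 (within the scatter), a number 5 percentage points higher from compound 2 to compound 3 (within the scatter) and a number 8 percentage points higher from compound 1 to compound 3 (within the scatter). Compound 4 `COc1cccc(/C=C/C(=O)c2c(O)cc(OC)cc2OC)c1` differs from compound 2 by hydrogen in place of methyl on an oxygen on an aromatic ring. Within the data shown here, no measured step changes that oxygen; the closest comparison is the methoxy-to-hydrogen change on an aromatic carbon, which lay within the scatter. The expected step is therefore a number 2 percentage points higher from compound 2 to compound 4 (within the scatter), with no change beyond the scatter. In this assay compound 4 is estimated at 42%, between 22% and 62%.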

Compound 4, a percentage reported as activity, at one concentration (the size of the read-out at that concentration, not a potency): 56%
For compound 4 the middle estimate is 14 percentage points below the measured one; measured number inside the range.
By their numbers in this assay, from the lowest: compounds 1, 2 and 3 (each within the scatter of the next); then compound 4.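

In this assay, among these compounds, the change from methoxy to hydroxy gives a number 16 percentage points higher from compound 2 to compound 4 (beyond the scatter), the only step so far to pass the scatter, and here the higher number stands for a weaker effect. Among the compounds shown here, this oxygen's methyl group therefore counts for more at the one concentration tested than any change among the earlier compounds. Nothing available explains this drop.

Going by these compounds, it remains open whether an ethoxy group or an amine in the same place would keep the effect of compound 2 or lose it as compound 4 does. On these data alone, the same swap at the other methoxy groups also remains open.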